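Dichlorophenyl re-entry on the triazolone piperidine series

This account rests on a few compounds, and the source may have more. Where it says the series, first, only, none or still open, it means among the compounds named here.

Going by the values given here, compound 3 `C[C@@H](O[C@H]1CCCN(Cc2n[nH]c(O)n2)[C@H]1c1ccccc1)c1ccccc1` gives 5.9 nM in a functional assay on microsomes from liver for antagonist activity at Substance-P receptor (Rattus norvegicus) (on this read-out higher numbers stand for weaker inhibition and lower numbers for stronger inhibition), the second highest of the three numbers known. Compound 1 `C[C@H](O[C@H]1CCCN[C@H]1c1ccccc1)c1cc(Cl)cc(Cl)c1` gives 85 nM and compound 2 `C[C@@H](O[C@H]1CCCN(Cc2n[nH]c(O)n2)[C@H]1c1ccccc1)c1cc(Cl)cc(Cl)c1` gives 0.09 nM in this assay. Compound 4 `C[C@H](O[C@H]1CCCN(Cc2n[nH]c(O)n2)[C@H]1c1ccccc1)c1cc(Cl)cc(Cl)c1` is not yet measured; it differs from compound 3 by 1-(3,5-dichlorophenyl)ethyl in place of 1-phenylethyl on an oxygen on a saturated carbon. Compound 4 thus carries the same group as compound 2, although the two structures are not identical, so the match is not exact. Among the compounds with values here, the one measured step that bears on this change is the reverse one, a 66-fold higher number from compound 2 to compound 3 (1.82 log units; beyond the scatter), a large shift beyond the scatter. Going back from phenyl to 3,5-dichlorophenyl is therefore expected to lower the number strongly, with the estimate for compound 4 deliberately left less sharp than a plain reversal because of the unresolved difference between compound 4 and compound 2 at 0.09 nM. The expected step is a 15-fold lower number from compound 3 to compound 4 (1.17 log units; beyond the scatter). Compound 4 is estimated at 0.4 nM in this assay, with a likely range from 0.07 nM to 3 nM.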

Compound 4, half-maximal inhibitory concentration: 25 nM
Estimate against measurement, compound 4: 63-fold (1.80 log units) below; measured number above the stated range.
By their numbers in this assay, from the lowest: compound 2; then compound 3; then compound 4; then compound 1.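

In this assay 1-(3,5-dichlorophenyl)ethyl in place of 1-phenylethyl gives a 4.2-fold higher number from compound 3 to compound 4 (0.63 log units; beyond the scatter) here, so that group alone does not secure a low number. With this same configuration, (5-hydroxy-1H-1,2,4-triazol-3-yl)methyl in place of hydrogen on the amine nitrogen in a ring gives only a 3.4-fold lower number from compound 1 to compound 4 (0.53 log units; beyond the scatter) in the same read-out. The low number of compound 2 depends on the stereocentre at the saturated chain carbon, with a 280-fold higher number from compound 2 to compound 4 (2.44 log units; beyond the scatter) on changing that centre alone: the fact that compounds 2 and 4 differ only in the configuration as drawn.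

Still open, as far as these compounds go, is whether a single chlorine on the phenyl ring shows the same dependence on configuration. Also open, from the compounds shown here alone, is whether a carboxylic acid or a primary amide could replace (5-hydroxy-1H-1,2,4-triazol-3-yl)methyl on the amine nitrogen in a ring and keep the low number of compound 2 .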